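A Terminal Aryl Swap Carried Onto a Second Core

The compounds below may be only part of what the source reports. "The series", "measured", "known", "first", "only" and "open" are said of these compounds alone.

Compound 1 `Cc1ccc2[nH]c(-c3ccc(-c4ccc(-c5cccc(Cl)c5)cc4)cc3)nc2c1` and compound 2 `COc1ccc(-c2ccc(-c3ccc(-c4nc5cc(C)ccc5[nH]4)cc3)cc2)cc1OC` share one core and differ only in the terminal ring. In a functional assay on HOP-62 cells (Homo sapiens) for inhibition, read by sulforhodamine B assay (a higher number here means a weaker inhibitor of growth, a lower number a stronger inhibitor of growth), compound 1 gives 2740 nM, and compound 2 gives 2120 nM. The change between them is 3,4-dimethoxyphenyl in place of 3-chlorophenyl on an aromatic carbon and it made a step of a 1.3-fold lower number from compound 1 to compound 2 (0.11 log units; within the scatter).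

Compound 3 `Oc1cccc2[nH]c(-c3ccc(-c4ccc(-c5cccc(Cl)c5)cc4)cc3)nc12` carries the same 3-chlorophenyl group on a different core; the difference between the two cores is not broken down here. In this assay compound 3 gives 2260 nM, a number that sits within the scatter of both compound 1 and compound 2, so no order among the three can be read from these values.

Compound 4 `COc1ccc(-c2ccc(-c3ccc(-c4nc5c(O)cccc5[nH]4)cc3)cc2)cc1OC` has not yet been measured in this assay. Among the compounds with values here, it differs from compound 3 by 3,4-dimethoxyphenyl in place of 3-chlorophenyl on an aromatic carbon, which is the same change as the one between compound 1 and compound 2, placed in the same way. Because the earlier step was only a 1.3-fold lower number from compound 1 to compound 2 (0.11 log units; within the scatter), a like step is expected for compound 4, a 1.3-fold lower number from compound 3 to compound 4 (0.10 log units; within the scatter), staying within the scatter. Compound 4 is therefore estimated at 1800 nM, with a likely range from 900 nM to 3600 nM.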

Compound 4, concentration for 50% growth inhibition: 2210 nM
Compound 4: middle estimate off by 1.2-fold (0.09 log units), on the low side; measured number inside the range.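

In this assay the same swap on the second core gave a 1.0-fold lower number from compound 3 to compound 4 (0.01 log units; within the scatter) and, with 3,4-dimethoxyphenyl held constant, the change of core gave a 1.0-fold higher number from compound 2 to compound 4 (0.02 log units; within the scatter). Set side by side, the steps on the two cores do not differ: the same change on two cores in this assay, a 1.3-fold lower number (0.11 log units; within the scatter) from compound 1 to compound 2 and a 1.0-fold lower number (0.01 log units; within the scatter) from compound 3 to compound 4, 1.3-fold (0.10 log units) apart, within the scatter of two such steps. This shows that, among these four compounds, replacing 3-chlorophenyl with 3,4-dimethoxyphenyl left the number within the scatter on both cores, but it does not show that the change has the same effect on both, as neither step is large enough to be told from the scatter, so the agreement is only one between two steps that cannot be distinguished from no change.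

The compounds shown leave open whether a terminal change that gives a step beyond the scatter would carry from one core to the other at a similar size. They also leave open what would happen with other groups on the terminal ring, such as an amine or a carboxylic acid, and whether either core would then respond in the same way.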